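Branched or straight side chain on a bile acid receptor antagonist

This account rests on a few compounds, and the source may have more. Where it says the series, first, only, none or still open, it means among the compounds named here.

Measured compounds:
Compound 1 `CCCCc1cc(C(C)=O)c(OCc2ccccc2)cc1OCCCCCC(C)(C)c1nnn[nH]1`: 7800 nM
Compound 2 `CCCc1cc(C(C)=O)c(O)cc1OCCCCCC(C)(C)c1nnn[nH]1`: 25200 nM
Compound 3 `CC(=O)c1cc(CC(C)C)c(OCCCCCC(C)(C)c2nnn[nH]2)cc1O`: 5800 nM

In an assay on isolated protein for antagonist activity at Bile acid receptor (Homo sapiens), read by HTRF, with a stated time of 30 min (a higher number here means a weaker inhibitor, a lower number a stronger inhibitor), compound 3 gives the lowest of the three numbers; compound 1 lies within the scatter of it, while compound 2 sits clearly higher. Compound 4 `CCCCc1cc(C(C)=O)c(O)cc1OCCCCCC(C)(C)c1nnn[nH]1` is not yet measured. It differs from compound 3 by propyl in place of isopropyl on a saturated chain carbon bound to an aromatic carbon, so the same atoms are arranged as a straight rather than a branched chain. For the measured compounds named here, the only measured step touching this chain is a 4.3-fold lower number from compound 2 to compound 3 (0.64 log units; beyond the scatter), which added a carbon as a branch. Going by the values given here, no measured step rearranges a chain without changing its size, so the direction is uncertain. A modest rise in the number, a 1.7-fold higher number from compound 3 to compound 4 (0.24 log units; within the scatter), is expected, and compound 4 is estimated at 10000 nM, between 3500 nM and 30000 nM.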

Compound 4, half-maximal inhibitory concentration: 1500 nM
Estimate against measurement, compound 4: 6.7-fold (0.82 log units) above, outside the stated range (below it).
By their numbers in this assay, from the lowest: compound 4; then compounds 3 and 1 (each within the scatter of the next); then compound 2.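

At this position, the arrangement of the atoms matters and not only their number: straight butyl in place of branched isobutyl, with the same atoms, gives (a 3.9-fold lower number from compound 3 to compound 4 (0.59 log units; beyond the scatter)). Adding the end methyl that turns the shorter straight chain into butyl gives (a 17-fold lower number from compound 2 to compound 4 (1.23 log units; beyond the scatter)). With butyl in place, the free hydroxyl also compares well with its benzyl ether, as hydrogen in place of benzyl gives (a 5.2-fold lower number from compound 1 to compound 4 (0.72 log units; beyond the scatter)). Nothing available here explains why the straight chain gives the lower number. On these data alone, whether pentyl or a longer chain would lower the number further remains open, as does the effect of a ring such as cyclopropyl on this chain.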